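The source may hold more compounds than are shown below. What is called first, only, known or untested is meant among the compounds shown, and "the series" means these compounds.

Measured so far:
- compound 1 `COc1ccc(/C=C/C(=O)c2ccc(OCCn3cc(CN4C(=O)/C=C/C(C)(C)C/C=C(\C)CC/C=C/4C)nn3)cc2O)cc1`: 1.21 ug/mL
- compound 2 `COc1ccccc1/C=C/C(=O)c1ccc(OCCn2cc(CN3C(=O)/C=C/C(C)(C)C/C=C(\C)CC/C=C/3C)nn2)cc1O`: 1.1 ug/mL
- compound 3 `COc1ccc(/C=C/C(=O)c2ccc(OCCCN3C(=O)/C=C/C(C)(C)C/C=C(\C)CC/C=C/3C)cc2)cc1`: 1.3 ug/mL

Not yet measured:
- compound 4 `COc1ccccc1/C=C/C(=O)c1ccc(OCCCN2C(=O)/C=C/C(C)(C)C/C=C(\C)CC/C=C/2C)cc1`

In a functional assay on P338 cells (Mus musculus) for antiproliferative activity (on this read-out lower numbers stand for stronger inhibition and higher numbers for weaker inhibition), compound 3 gives 1.3 ug/mL, within the scatter of both compound 1 and compound 2, so the three values cannot be ranked.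

The change to compound 4 is 2-methoxyphenyl in place of 4-methoxyphenyl on a double-bonded chain carbon bound to a double-bonded chain carbon, on a double-bonded chain carbon bound to a double-bonded chain carbon. The same exchange has been measured only once, on a different linker: a 1.1-fold lower number from compound 1 to compound 2 (0.04 log units; within the scatter), which lies within the scatter. This single pair gives thin support, but no step beyond the scatter is expected in this assay.

The expected change is a 1.1-fold lower number from compound 3 to compound 4 (0.03 log units; within the scatter).

For compound 4 the estimated value is 1.2 ug/mL, with an expected range of 0.7 ug/mL to 2 ug/mL.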

Compound 4, half-maximal inhibitory concentration: 0.83 ug/mL
Estimate against measurement, compound 4: 1.4-fold (0.16 log units) above; measured number inside the range.
By their numbers in this assay, from the lowest: compounds 4, 2, 1 and 3 (each within the scatter of the next).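

In this assay, 2-methoxyphenyl in place of 4-methoxyphenyl gives a 1.6-fold lower number from compound 3 to compound 4 (0.19 log units; within the scatter), so the exchange also stays within the scatter on a second core. The exchange now has two readings, and they do not differ beyond the scatter: the same change on two cores in this assay, a 1.1-fold lower number (0.04 log units; within the scatter) from compound 1 to compound 2 and a 1.6-fold lower number (0.19 log units; within the scatter) from compound 3 to compound 4, 1.4-fold (0.15 log units) apart, within the scatter of two such steps. At this place on the double-bonded chain carbon, neither core separates the two methoxyphenyl groups.

From the compounds shown here alone, it remains open whether a group other than methoxy on the phenyl ring, such as an amine or a carboxylic acid, would give a step beyond the scatter.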